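A Heavier Aryl Group on the Shared Core

A few compounds are considered here, and "the series" means these few. Any claim that something is new, unique, unknown or untested is made for them only; others in the source may bear on it.

Of the compounds shown here, two have so far been measured in an assay on HEK293 cells for displacement of a labelled ligand from Melanocortin receptor 4 (Homo sapiens); a higher number here means a weaker inhibitor, a lower number a stronger inhibitor. Compound 1 (`CC(=O)N1C[C@@H](C(=O)N2CCN(c3ccc(C)cc3[C@@H](NC(=O)CCN(C)C)C(C)C)CC2)[C@H](c2ccc(Cl)cc2)C1`) gives 7.6 nM there, and compound 2 (`CC(C)[C@H](NC(=O)CCN(C)C)c1cccc(F)c1N1CCN(C(=O)[C@@H]2CN(C(C)C)C[C@H]2c2ccc(Cl)cc2)CC1`) gives 5.3 nM. Compound 2 holds the lower of the two numbers, but its gap to compound 1 lies within the scatter of this kind of measurement, so the two cannot be placed in order.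

Compound 3 (`CC(C)[C@H](NC(=O)CCN(C)C)c1cccc(F)c1N1CCN(C(=O)[C@@H]2CN(C(C)C)C[C@H]2c2ccc(C(F)(F)F)c(F)c2)CC1`) has not yet been tested in this assay. It differs from compound 2 in a single place: 3-fluoro-4-(trifluoromethyl)phenyl in place of 4-chlorophenyl on a saturated ring carbon. The group that enters brings more heavy atoms than the group that leaves, and neither carries a hydrogen-bond donor or acceptor. Among the compounds with values here, no measured pair in this set shows what such an exchange does, so there is no step to lean on.

The step of a 1.5-fold higher number from compound 2 to compound 3 (0.18 log units; within the scatter) is therefore expected to be small, if anything toward a somewhat higher number, and may well fall within the scatter. The estimate for compound 3 in this assay is 8 nM, with a range from 2.5 nM to 25 nM.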

Compound 3, inhibition constant: 51 nM
Estimate against measurement, compound 3: 6.4-fold (0.80 log units) below; measured number above the stated range.
By their numbers in this assay, from the lowest: compounds 2 and 1 (each within the scatter of the next); then compound 3.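

In this assay, within the data shown here, the aryl group on the saturated ring carbon proves to matter: 3-fluoro-4-(trifluoromethyl)phenyl in place of 4-chlorophenyl gives a 9.6-fold higher number from compound 2 to compound 3 (0.98 log units; beyond the scatter) and is the only step in this set. Compound 1 and compound 2 both carry 4-chlorophenyl, so neither could show how the number responds to a change at this position, whereas this pair shows that the position does not tolerate every aryl group equally. No measurement shown here accounts for the size of the step.

The exchange alters two things at once, since the chlorine leaves while a trifluoromethyl group and a fluorine enter, and the compounds shown do not tell which of these carries the step. From the compounds shown here alone, it remains open whether a phenyl ring bearing only the trifluoromethyl group, or one keeping the chlorine and gaining a fluorine, would stay close to compound 2 or move with compound 3.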